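Moving a hydroxy group on a growth inhibitor

The source may report more compounds than this note shows. Statements on the series, on what has been measured and on what is new or still open speak of the compounds shown alone.

Among the compounds with values here, in a functional assay on SNB-75 cells (Homo sapiens) for inhibition, read by sulforhodamine B assay, with a stated time of 48 h (on this read-out higher numbers stand for weaker inhibition of growth and lower numbers for stronger inhibition of growth), compound 1 `O=C(Cc1csc2nc(-c3ccc(Br)cc3)cn12)N/N=C/c1ccccc1` gives 31600 nM and compound 2 `O=C(Cc1csc2nc(-c3ccc(Br)cc3)cn12)N/N=C/c1ccccc1O` gives 12900 nM, the lower of the two numbers so far. Within the data shown here, the only measured step, a 2.4-fold lower number from compound 1 to compound 2 (0.39 log units; beyond the scatter), came from hydroxy in place of hydrogen on an aromatic carbon. Compound 3 `O=C(Cc1csc2nc(-c3ccc(Br)cc3)cn12)N/N=C/c1ccc(O)cc1` brings a different kind of change: 4-hydroxyphenyl in place of 2-hydroxyphenyl on a carbon with a double bond to nitrogen. In words, 4-hydroxyphenyl stands in place of 2-hydroxyphenyl on a carbon with a double bond to nitrogen. Among the measured compounds shown here, the measured step bears on this only indirectly, as no measured compound carries 4-hydroxyphenyl. Compound 3 keeps a hydroxy group, so a value near compound 2 seems likeliest, with a drift toward compound 1 possible. The expected result is a 1.4-fold higher number from compound 2 to compound 3 (0.14 log units; within the scatter), with no shift beyond the scatter anticipated. The estimate for compound 3 is 18000 nM, with an expected range from 8000 nM to 40000 nM.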

Compound 3, concentration for 50% growth inhibition: < 100000 nM
Compound 3: a limit, no number; the forecaster's own chance of this, stated with the estimate: 10%; the middle value lies beyond the limit too.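

In this assay compound 3 gives < 100000 nM, which is a limit and not a number, so its steps from compound 1 and compound 2 cannot be read. The compounds shown leave open whether 4-hydroxyphenyl serves growth inhibition better or worse than 2-hydroxyphenyl.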